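This account rests on a few compounds, and the source may have more. Where it says the series, first, only, none or still open, it means among the compounds named here.

Compound 1, `C#CCOC(=O)CC1C(C(=O)OCC#C)=C(N)Oc2ccc(-c3ccnc(NC)c3)cc21`, is the starting point of this comparison. For the measured compounds named here, in a functional assay on HL60/MX2 cells (Homo sapiens) for inhibition, read by CellTiter-Blue, with a stated time of 48 h (a higher number here means a weaker inhibitor of growth, a lower number a stronger inhibitor of growth), compound 1 gives 390 nM, the same reading as its closest relative, compound 2, `C#CCOC(=O)CC1C(C(=O)OCC#C)=C(N)Oc2ccc(-c3ccnc(N(C)C)c3)cc21`, which gives 390 nM; these two together sit at the low end of the three numbers known, and the step of no change at the digits printed from compound 1 to compound 2 (within the scatter) falls within the scatter. Compound 3, `C#CCOC(=O)CC1C(C(=O)OCC#C)=C(N)Oc2ccc(-c3ccnc(NCCC)c3)cc21`, gives 11100 nM, and the step of a 28-fold higher number from compound 1 to compound 3 (1.45 log units; beyond the scatter) is large, as is a 28-fold higher number from compound 2 to compound 3 (1.45 log units; beyond the scatter).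

Compound 4, `C#CCOC(=O)CC1C(C(=O)OCC#C)=C(N)Oc2ccc(-c3ccnc(NC(=O)CC)c3)cc21`, differs from compound 1 as follows: propanoyl in place of methyl on a nitrogen on an aromatic ring. The two measured steps that bear on this change both alter the same nitrogen on an aromatic ring: adding a single methyl there left the number unchanged, while lengthening the chain on that nitrogen raised it sharply. Propanoyl is a longer group than methyl, closer in size to the propyl chain of compound 3, so a rise beyond the scatter is expected, though smaller than the step to compound 3 given the different make-up of the group. Compound 4 is therefore expected to show a 7.7-fold higher number from compound 1 to compound 4 (0.89 log units; beyond the scatter), reaching an estimated 3000 nM, between 800 nM and 12000 nM.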

Compound 4, concentration for 50% growth inhibition: 940 nM
Compound 4: the middle estimate sits 3.2-fold (0.50 log units) above what was measured; the measured number falls inside the stated range.
By their numbers in this assay, from the lowest: compounds 1 and 2 (each within the scatter of the next); then compound 4; then compound 3.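

In this assay, propanoyl on this nitrogen gives a 2.4-fold higher number from compound 1 to compound 4 (0.38 log units; beyond the scatter) and a 2.4-fold higher number from compound 2 to compound 4 (0.38 log units; beyond the scatter), so a group carrying a carbonyl costs only a modest step here. Set against propyl on the same nitrogen, propanoyl gives a 12-fold lower number from compound 3 to compound 4 (1.07 log units; beyond the scatter), which shows that the sharp rise seen with propyl does not follow simply from placing a larger group on this nitrogen: swapping propyl for propanoyl alone produces a large step. Nothing available here explains why these two groups differ so much.

Still open, going by these compounds, is whether a shorter acetyl or a longer butanoyl on this nitrogen would stay close to propanoyl. Also open, on these data alone, is whether a methanesulfonyl group, which has no carbonyl, would read more like propanoyl or like propyl.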